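Methyl on the anilino ring: a repeated change

This account rests on a few compounds, and the source may have more. Where it says the series, first, only, none or still open, it means among the compounds named here.

Measured so far:
compound 1 `COc1cc(OC)c2sc(-c3ccc(N/C=C\C(=O)c4ccc(OC)c([N+](=O)[O-])c4)c(C)c3)nc2c1`: 9390 nM
compound 2 `COc1cc(OC)c2sc(-c3ccc(N/C=C\C(=O)c4ccc(OC)c([N+](=O)[O-])c4)cc3)nc2c1`: 12900 nM
compound 3 `COc1ccc2nc(-c3ccc(N/C=C\C(=O)c4cc(OC)c(OC)c([N+](=O)[O-])c4)cc3)sc2c1`: 16100 nM

Three compounds have been run in a functional assay on HeLa cells (Homo sapiens) for antiproliferative activity, read by sulforhodamine B assay, with a stated time of 48 h; on this read-out lower numbers stand for stronger inhibition and higher numbers for weaker inhibition. Compound 1 gives 9390 nM and compound 2 gives 12900 nM; the pair differs in one place, (methyl in place of hydrogen on an aromatic carbon), and the step is a 1.4-fold lower number from compound 2 to compound 1 (0.14 log units; within the scatter). Compound 3 gives 16100 nM in this assay. Compound 3 and compound 2 are built from the same atoms joined differently; the difference between the two cores is not broken down here, and the two values lie within the scatter of each other, so no order is claimed.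

Compound 4 `COc1ccc2nc(-c3ccc(N/C=C\C(=O)c4cc(OC)c(OC)c([N+](=O)[O-])c4)c(C)c3)sc2c1` has not yet been measured. It stands to compound 3 as compound 1 stands to compound 2: methyl in place of hydrogen on an aromatic carbon. The two place descriptions differ in what lies meta to the new group, a large group in compound 1 against a 6-methoxy-1,3-benzothiazol-2-yl group in compound 4, so this is the same kind of change rather than the same change.

Going by the values given here, with only one earlier instance of this change, the expectation rests on that single step, a 1.4-fold lower number from compound 2 to compound 1 (0.14 log units; within the scatter), which lies within the scatter. The step from compound 3 to compound 4 is therefore expected to be small, a 1.4-fold lower number from compound 3 to compound 4 (0.15 log units; within the scatter), in this assay. Compound 4 is estimated at 11500 nM, with a likely range from 6000 nM to 25000 nM.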

Compound 4, half-maximal inhibitory concentration: 12100 nM
Compound 4: middle estimate off by 1.1-fold (0.02 log units), on the low side, and the stated range covers the measured number.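

In this assay, going by these compounds alone, methyl in place of hydrogen on an aromatic carbon, ortho to a large group and meta to a 6-methoxy-1,3-benzothiazol-2-yl group, gives a 1.3-fold lower number from compound 3 to compound 4 (0.12 log units; within the scatter), so on this second core the change again produces no step that can be told apart from repeat measurement. The two instances of the change agree in size, and on this evidence the change carries from one core to the other as a step too small to read: the same change on two cores in this assay, a 1.4-fold lower number (0.14 log units; within the scatter) from compound 2 to compound 1 and a 1.3-fold lower number (0.12 log units; within the scatter) from compound 3 to compound 4, 1.0-fold (0.01 log units) apart, within the scatter of two such steps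

This does not show that the methyl group strengthens inhibition, since neither step stands clear of the scatter, and agreement between two such small steps says little about how the change would behave on a core outside these two or in a different assay.

Open, on these data alone, is whether another group on the same aromatic carbon, such as chlorine, methoxy, ethyl or an amine, would give a step beyond the scatter on either core. Also open, as far as these compounds go, is whether replacing the nitro group with a nitrile, an amine or a carboxylic acid would move the numbers on these cores, and whether the methyl step would stay the same on such compounds.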